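Two Inactive Nucleoside Analogues and a Smaller Aryl Ring

A few compounds are considered here, and "the series" means these few. Any claim that something is new, unique, unknown or untested is made for them only; others in the source may bear on it.

Compound 1 `O=c1[nH]cnc2c1c(-c1cc3ccccc3o1)cn2[C@@H]1O[C@H](CO)[C@@H](O)[C@H]1O`: in a functional assay on HepG2 cells (Homo sapiens) for antiproliferative activity, read by XTT assay, with a stated time of 72 h (a lower number here means a stronger inhibitor, a higher number a weaker inhibitor), compound 1 gives only the limit > 20000 nM.
Compound 2 `CN(C)c1ncnc2c1c(-c1cc3ccccc3o1)cn2[C@@H]1O[C@H](CO)[C@@H](O)[C@H]1O`: in this assay compound 2 gives only the limit > 20000 nM.

Among the measured compounds shown here, both measured compounds share a core carrying a sugar and a 1-benzofuran-2-yl group; compound 1 and compound 2 differ on the six-membered ring of the core, and no step between them is counted, so their two values can only be set side by side. Compound 1 stands at the limit of this assay rather than at a number, so it cannot be ranked against compound 2. The whole of the evidence is the limit of > 20000 nM in this assay, at which 2 of the 2 values shown sit: every value sits at that limit.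

For the measured compounds named here, compound 3 `O=c1[nH]cnc2c1c(-c1ccsc1)cn2[C@@H]1O[C@H](CO)[C@@H](O)[C@H]1O` is the untested member. thiophen-3-yl in place of 1-benzofuran-2-yl on an aromatic carbon No measured step informs this change, and since compound 1 gives only the limit > 20000 nM, no direction can be read from the data. The step expected from this change, a number no higher from compound 1 to compound 3 (the limit leaves the size open), is none beyond the scatter. Compound 3 is expected to give 20000 nM, within 8000 nM to 60000 nM, most likely again reported only as a limit.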

Compound 3, half-maximal inhibitory concentration: > 15000 nM
Compound 3 was reported as a limit; the forecaster's own chance of this, stated with the estimate: 80%; the middle value lies beyond the limit too.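

In this assay compound 3 gives only the limit > 15000 nM. Compound 1 also gives only a limit, > 20000 nM, so the step from compound 1 to compound 3 cannot be read. The compounds shown leave open whether swapping 1-benzofuran-2-yl for thiophen-3-yl changes antiproliferative activity in any way.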